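The source may hold more compounds than are shown below. What is called first, only, known or untested is meant among the compounds shown, and "the series" means these compounds.

In a functional assay on SK-OV-3 cells (Homo sapiens) for inhibition, read by sulforhodamine B assay, with a stated time of 48 h (a lower number here means a stronger inhibitor of growth, a higher number a weaker inhibitor of growth), compound 1 `O=C(Nc1cccc(-n2cc(-c3ccncc3)c(-c3ccc(Cl)c(O)c3)n2)c1)Nc1ccc(Cl)c(Cl)c1` gives 1200 nM, while compound 2 `COc1cc(-c2nn(-c3cccc(NC(=O)c4ccc(Cl)c(C(F)(F)F)c4)c3)cc2-c2ccncc2)ccc1Cl` gives 9290 nM; compound 2 thus carries the higher of the two numbers, and its gap to compound 1 lies beyond the usual scatter. Compound 3 `COc1cc(-c2nn(-c3cccc(NC(=O)c4cccc(C(F)(F)F)c4)c3)cc2-c2ccncc2)ccc1Cl` has not been measured in this assay. It differs from compound 2 by a hydrogen in place of chloro on an aromatic carbon, the group on the amide side going from 4-chloro-3-(trifluoromethyl)phenyl to 3-(trifluoromethyl)phenyl. Within the data shown here, no measured pair in this set shows what the loss of such a chloro does, so the expectation rests only on compound 2 itself. The step from compound 2 to compound 3 is expected to be small, a 1.3-fold higher number from compound 2 to compound 3 (0.11 log units; within the scatter), likely a slight rise or none beyond the scatter. Compound 3 is therefore estimated at 12000 nM in this assay, with a range from 4000 nM to 40000 nM.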

Compound 3, concentration for 50% growth inhibition: 2290 nM
Compound 3: middle estimate off by 5.2-fold (0.72 log units), on the high side; measured number below the stated range.
By their numbers in this assay, from the lowest: compounds 1 and 3 (each within the scatter of the next); then compound 2.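

In this assay, replacing the chloro on the 4-chloro-3-(trifluoromethyl)phenyl group with hydrogen gives a 4.1-fold lower number from compound 2 to compound 3 (0.61 log units; beyond the scatter), a modest step beyond the scatter. This position, ortho to a trifluoromethyl group, therefore responds to the change, and the compound with hydrogen there is the stronger inhibitor of growth of the pair. Among these compounds, this is the first single change that can be read in the set, and no measurement at hand bears on what lies behind it.

The compounds shown leave open whether any group at this position would give a higher number than hydrogen, as a fluoro, a methyl or a methoxy there would show. They also leave open whether losing a chloro would have a similar effect in the setting of compound 1.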